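The compounds below may be only part of what the source reports. "The series", "measured", "known", "first", "only" and "open" are said of these compounds alone.

Three nucleoside analogues sharing one core were tested for toxicity toward liver-derived cells in a functional assay on Huh-7 cells (Homo sapiens) for cytotoxicity, read by MTT assay, with a stated time of 3 days; on this read-out higher numbers stand for lower toxicity in this test and lower numbers for higher toxicity in this test. Compound 1, `CC(=O)N(Cc1ccccc1)Cc1ncnc2c1ncn2[C@@H]1O[C@H](CO)[C@@H](O)[C@H]1O`, carries an acetylated benzylamine arm on its core. In this assay compound 1 gives only a limit of the measurement, > 100000 nM. Compound 2, `OC[C@H]1O[C@@H](n2cnc3c(CSCc4ccccc4)ncnc32)[C@H](O)[C@@H]1O`, bears a benzylsulfanyl group in the same place. In this assay compound 2 likewise reaches only a limit, > 100000 nM. Compound 3, `O=C(O)CNCc1ncnc2c1ncn2[C@@H]1O[C@H](CO)[C@@H](O)[C@H]1O`, has (carboxymethyl)amino on a saturated chain carbon bound to an aromatic carbon. In this assay compound 3 again shows only a limit, > 100000 nM. Within the data shown here, compound 3 therefore stands where the other two stand, and the single step between two of them, a step that the two limits leave unreadable from compound 2 to compound 3, cannot be read because the limit of > 100000 nM in this assay, at which 3 of the 3 values shown sit, holds every value shown.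

Compound 4, `OC[C@H]1O[C@@H](n2cnc3c(Cn4cccn4)ncnc32)[C@H](O)[C@@H]1O`, differs from compound 3 by 1H-pyrazol-1-yl in place of (carboxymethyl)amino on a saturated chain carbon bound to an aromatic carbon. Among the measured compounds shown here, no measured step bears on this change in a readable way, since each compound so far sits at the limit rather than at a number. The expectation is that the step of a number no higher from compound 3 to compound 4 (the limit leaves the size open) stays within the scatter, with compound 4 most likely again reported as a limit. Compound 4 is thus estimated at 100000 nM, expected to lie between 40000 nM and 300000 nM.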

Compound 4, half-maximal cytotoxic concentration: > 250000 nM
Compound 4 was reported as a limit; the forecaster's own chance of this, stated with the estimate: 85%; middle value at least 2.5-fold (0.39 log units) from the limit.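

In this assay compound 4 gives only a limit, > 250000 nM. Neither the change from compound 3 to compound 4 nor the change from compound 2 to compound 4 can therefore be read as a step. The compounds shown leave open at what concentration, if any, they harm these cells, and whether swapping these groups changes that.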